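A few compounds are considered here, and "the series" means these few. Any claim that something is new, unique, unknown or untested is made for them only; others in the source may bear on it.

Within the data shown here, the three compounds measured so far were all tested in a functional assay on HEK293 cells for agonist activity at G-protein coupled receptor 39 (Homo sapiens), read by scintillation proximity assay and inositol phosphate accumulation, with a stated time of 75 min, in the presence of a further agent that is not named here; on this read-out higher numbers stand for an effect only at larger amounts of compound and lower numbers for an effect already at smaller amounts. Compound 1 `Cc1nn(-c2ncnc3nc[nH]c23)c2c1C(OCC(=O)c1ccc(F)cc1)CC(=O)N2` gives 3 nM, the lowest of the three numbers. Compound 3 `Cc1nn(-c2ncnc3nc[nH]c23)c2c1C(C(=O)N(C)c1nccs1)CC(=O)N2`, which shares its core, gives 18 nM, a gap from compound 1 that lies beyond the usual scatter. Compound 2 `O=C1/C(=C/NCCCO)C(c2ccccc2)=NN1c1nc2ccccc2s1`, built on a different scaffold, gives 200 nM and sits furthest from compound 1. Compound 1 is therefore the most potent of the three, with both gaps larger than the scatter.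

Compound 4 `COc1ccc(CCOC2CC(=O)Nc3c2c(C)nn3-c2ncnc3nc[nH]c23)cc1` keeps the core of compound 1 and differs in a single place: 4-methoxybenzyl in place of (4-fluorophenyl)carbonyl on a saturated chain carbon bound to an oxygen on a saturated carbon. The group that leaves carries a carbonyl; the group that enters does not, and the two six-membered aromatic rings carry different substituents. No pair of measured compounds differs in exactly this way, so the size of the step has no direct precedent among these numbers. Starting from compound 1 and its value of 3 nM, a modest loss of activity is expected, with the estimated step of a 3.3-fold higher number from compound 1 to compound 4 (0.52 log units; beyond the scatter) pointing toward a higher number and likely somewhat beyond the scatter. Compound 4 is thus estimated at 10 nM, within a range of 3 nM to 40 nM.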

Compound 4, half-maximal effective concentration: 2 nM
Compound 4: the middle estimate sits 5.0-fold (0.70 log units) above what was measured; the whole stated range lies above it.
By their numbers in this assay, from the lowest: compounds 4 and 1 (each within the scatter of the next); then compound 3; then compound 2.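

In this assay, the exchange of (4-fluorophenyl)carbonyl for 4-methoxybenzyl on a saturated chain carbon bound to an oxygen on a saturated carbon gives a 1.5-fold lower number from compound 1 to compound 4 (0.18 log units; within the scatter). This is the first single-place step among the compounds shown, and it means that on the core of compound 1, the carbonyl of this side chain can go and the fluorine can give way to a methoxy group without the number moving beyond the usual scatter. Nothing measured here explains why the number holds across this change.

Both changes happen in the same step, so this pair cannot separate what the carbonyl and the ring substituent each contribute, and their separate effects might be small or might offset each other. It also leaves open whether the position tolerates a very different end to the chain, such as an amine, a carboxylic acid or a longer chain, or whether the number holds only for groups that end in a six-membered aromatic ring of carbon.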